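A Single Methyl Added to a Weak Starting Point

This account rests on a few compounds, and the source may have more. Where it says the series, first, only, none or still open, it means among the compounds named here.

Of the compounds shown here, three of one series have been tested in a functional assay on HL-60 cells (Homo sapiens) for inhibition, read by MTT assay, with a stated time of 72 h; a higher number here means a weaker inhibitor, a lower number a stronger inhibitor. Compound 1, with structure `Cc1ccc(N2CCN(C(=O)c3oc(C)nc3-c3ccccc3)CC2)cc1`, gives only a limit in this assay, > 1000 nM, which is not a number. Where compound 1 stands is told by the limit of > 1000 nM in this assay, at which 1 of the 3 values shown sits. Compound 2, with structure `CCc1nc(-c2cccc(F)c2)c(C(=O)N2CCN(c3cccc(Cl)c3)CC2)o1`, gives 317 nM in this assay. Compound 3, with structure `O=C(c1oc(C(F)(F)F)nc1-c1ccc(F)cc1)N1CCN(c2cccc(Cl)c2)CC1`, is reported in this assay as "not active" (no number reported), again without a number. No two of these compounds differ in only one place, so no single measured step can be drawn from them, and compound 2 is the only one with a value inside the measurable range.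

Compound 4, with structure `Cc1nc(-c2ccccc2)c(C(=O)N2CCN(c3ccc(C)c(C)c3)CC2)o1`, has not yet been measured. It differs from compound 1 by methyl in place of hydrogen on an aromatic carbon. One added methyl is a small change, and nothing measured in this set shows what such a change does here. The step that the limit leaves unreadable from compound 1 to compound 4 is expected to be none beyond the usual scatter. Compound 4 is therefore expected to give about 2000 nM in this assay, within a range from 700 nM to 6000 nM, and most likely to be reported again only as a limit.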

Compound 4, half-maximal inhibitory concentration: 43 nM
The estimate for compound 4 lay 47-fold (1.67 log units) above the measured number, outside the stated range (below it).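

Moving from the 4-methylphenyl to the 3,4-dimethylphenyl group adds one methyl on an aromatic carbon, and in this assay this gives an at least 23-fold lower number from compound 1 to compound 4 (1.36 log units; beyond the scatter), a large step beyond the scatter of repeated measurements. This position, ortho to a methyl group and meta to a large group, is therefore not indifferent in this one pair: a single added carbon separates a compound reported only as a limit from one with a number inside the measurable range. The true size of the step cannot be stated, because compound 1 has no exact value and only a limit: the limit of > 1000 nM in this assay, at which 1 of the 4 values shown sits.

Among the compounds shown, methyl is the only group at this position, so it remains open whether chlorine, a methoxy group, or a longer chain such as ethyl would give a similar result or a different one. On these data alone, it is also open whether the same methyl would have a comparable effect alongside the other changes seen in compound 2 and compound 3, since neither differs from compound 4 in only one place.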